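Naphthalen-1-yl in Place of 2-Methylphenyl on a Shared Core

A few compounds are considered here, and "the series" means these few. Any claim that something is new, unique, unknown or untested is made for them only; others in the source may bear on it.

Measured so far:
compound 1, `COc1cc(Br)c(C2C(C#N)=C(N)OC(c3c[nH]c4ccccc34)=C2C#N)cc1OC`, 18.5%
compound 2, `Cc1ccccc1C1C(C#N)=C(N)OC(c2c[nH]c3ccccc23)=C1C#N`, 10.4%

Both were tested in a functional assay, tested at 50 ug/mL; a lower number here means a weaker effect, a higher number a stronger effect of the compound at the concentration tested. Compound 2 gives 10.4%, and compound 1 gives 18.5%; the two lie within the usual scatter of each other, so neither can be called the stronger. Compound 3, `N#CC1=C(N)OC(c2c[nH]c3ccccc23)=C(C#N)C1c1cccc2ccccc12`, is not yet measured. It differs from compound 2 in one place: naphthalen-1-yl in place of 2-methylphenyl on a saturated ring carbon. Among the measured compounds shown here, no step between two measured compounds shows what such a change does, so no shift beyond the scatter is expected in this assay. The step from compound 2 to compound 3 is estimated at a number 3.6 percentage points higher from compound 2 to compound 3 (within the scatter). Compound 3 is thus expected to give 14%, between 4% and 30%.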

Compound 3, a percentage reported as activity, at one concentration (the size of the read-out at that concentration, not a potency): 4.7%
For compound 3 the middle estimate is 9.3 percentage points above the measured one; the measured number falls inside the stated range.
By their numbers in this assay, from the lowest: compounds 3, 2 and 1 (each within the scatter of the next, the first and the last beyond it).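

Among the compounds shown here, the first step that can be read at this position in this assay is a number 5.7 percentage points lower from compound 2 to compound 3 (within the scatter) when naphthalen-1-yl takes the place of 2-methylphenyl on the saturated ring carbon. Going from one six-membered aromatic ring to two at this carbon therefore leaves the read-out within the scatter. Nothing measured here offers an explanation for this result. On these data alone, it remains open whether a carboxylic acid or an amine on this carbon's aromatic ring would move the read-out beyond the scatter. A single step also cannot show whether the same change would behave alike with the other substituents of compound 1.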